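The compounds below may be only part of what the source reports. "The series", "measured", "known", "first", "only" and "open" are said of these compounds alone.

Measured so far:
compound 1, `CN(C)C(=O)c1cccnc1NCCCN1CCN(c2ccccc2O)CC1`: 63.1 nM
compound 2, `CN(C)C(=O)c1cccnc1NCCCN1CCN(c2ccccc2OCC2CC2)CC1`: 10 nM
compound 3, `CN(C)C(=O)c1cccnc1NCCCN1CCN(c2ccccc2-c2ncco2)CC1`: 25.1 nM

All three were tested in a functional assay on aorta for antagonist activity at Alpha-1D adrenergic receptor (Rattus norvegicus); on this read-out lower numbers stand for tighter binding and higher numbers for weaker binding. Compound 1 gives the highest number of the three: compound 3 lies closest to it, and compound 2 furthest away. Compound 4, `COc1cc(O)ccc1N1CCN(CCCNc2ncccc2C(=O)N(C)C)CC1`, has not yet been measured. It differs from compound 1 in one place: 4-hydroxy-2-methoxyphenyl in place of 2-hydroxyphenyl on an amine nitrogen in a ring. Two measured steps start from compound 1 and alter the same hydroxyphenyl group: a 6.3-fold lower number from compound 1 to compound 2 (0.80 log units; beyond the scatter) and a 2.5-fold lower number from compound 1 to compound 3 (0.40 log units; beyond the scatter). Both lowered the number. The larger of the two replaced the hydrogen on the oxygen of the aromatic ring with a cyclopropylmethyl group; compound 4 likewise carries an alkyl group, a methyl, on that oxygen, and in addition a second hydroxy on the ring. A modest lowering of the number in this assay is therefore expected, in the direction of compound 2 though not necessarily as far. Compound 4 is expected to give about 25 nM, within 8 nM to 80 nM, which would mean a 2.5-fold lower number from compound 1 to compound 4 (0.40 log units; beyond the scatter).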

Compound 4, dissociation constant: 79.4 nM
Beside the measured number, compound 4's estimate is 3.2-fold (0.50 log units) below it; the range from low to high includes it.
By their numbers in this assay, from the lowest: compound 2; then compound 3; then compounds 1 and 4 (each within the scatter of the next).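

In this assay, placing 4-hydroxy-2-methoxyphenyl where 2-hydroxyphenyl stood on the ring nitrogen gives a 1.3-fold higher number from compound 1 to compound 4 (0.10 log units; within the scatter), so this larger group leaves the read-out indistinguishable from that of the starting compound. The earlier steps shown here, a 6.3-fold lower number from compound 1 to compound 2 (0.80 log units; beyond the scatter) and a 2.5-fold lower number from compound 1 to compound 3 (0.40 log units; beyond the scatter), might have suggested that replacing the hydroxyphenyl group generally lowers the number, but compound 4 goes against that pattern, showing that the outcome depends on which group enters. Nothing measured here gives a reason for this result.

The compounds shown leave open what the methoxy and the 4-hydroxy each contribute, since both arrive together in compound 4. A plain 2-methoxyphenyl group, carrying the methoxy without the 4-hydroxy, would help to separate the two.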